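The compounds below may be only part of what the source reports. "The series", "measured", "known", "first", "only" and "open" are said of these compounds alone.

Among the measured compounds shown here, compound 3, `CC(Oc1ccc(Oc2ccc(C(F)(F)F)cc2)cc1)C(=O)Cn1nnc(-c2ccc(C(=O)O)cc2)n1`, stands second highest of the three numbers so far in a physicochemical assay for lipophilicity, read by HPLC, tested at 5 mM (a higher number here means a more lipophilic compound, a lower number a more polar compound), giving 3.5; its nearest neighbour is compound 2, `CC(Oc1ccc(Oc2ccc(F)cc2)cc1)C(=O)Cn1nnc(-c2ccc(C(=O)O)cc2)n1`, at 2.7, and furthest is compound 1, `CC(Oc1ccc(-c2ccccc2)cc1)C(=O)Cn1nnc(-c2ccccc2)n1`, at 5.3. Compound 4, `CC(Oc1ccc(-c2ccccc2)cc1)C(=O)Cn1nnc(-c2ccc(C(=O)O)cc2)n1`, differs from compound 3 by phenyl in place of 4-(trifluoromethyl)phenoxy on an aromatic carbon. For the measured compounds named here, no measured step makes this same change; the only step available, a number 0.80 log units higher from compound 2 to compound 3 (beyond the scatter), touches the same phenoxy position and was modest. Compound 1 carries phenyl at that place but lacks the carboxylic acid, so it sets no direct reference. Compound 4 is therefore expected to sit lower than compound 3 in this assay, with a step of a number 0.70 log units lower from compound 3 to compound 4 (beyond the scatter). The estimate for compound 4 is 2.8, with a range from 2.2 to 3.4.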

Compound 4, partition coefficient: 2.6
Beside the measured number, compound 4's estimate is 0.20 log units above it, within the range that was stated.
By their numbers in this assay, from the lowest: compounds 4 and 2 (each within the scatter of the next); then compound 3; then compound 1.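

In this assay, phenyl in place of 4-(trifluoromethyl)phenoxy gives a number 0.90 log units lower from compound 3 to compound 4 (beyond the scatter), while phenyl in place of 4-fluorophenoxy gives a number 0.10 log units lower from compound 2 to compound 4 (within the scatter), so these two groups are not told apart here. With phenyl held on that aromatic carbon, carboxy in place of hydrogen gives a number 2.70 log units lower from compound 1 to compound 4 (beyond the scatter), a much larger step than either swap. Nothing measured here offers a reason for these steps. As far as these compounds go, whether an amine or a methoxy group on that aromatic carbon would follow phenyl stays open. So does whether an amide in place of the carboxylic acid would give a step of similar size.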